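Chain extension from compound 3 to compound 4

This account rests on a few compounds, and the source may have more. Where it says the series, first, only, none or still open, it means among the compounds named here.

In a functional assay on FL5.12 cells (Mus musculus) for cytotoxicity, read by flow cytometry, with a stated time of 48 h (on this read-out higher numbers stand for weaker inhibition and lower numbers for stronger inhibition), compound 3 (`CCCC/C=C/c1ccc(CO[C@H]2CN[C@H](CO)C2)cc1`) gives 5700 nM. Compound 2 (`CCCC/C=C/c1ccc(CO[C@@H]2CN[C@@H](CO)C2)cc1`) gives 5500 nM, level with compound 3 within the scatter. Compound 1 (`CCCCCCCCCCCCC/C=C/[C@@H](O)[C@H](CO)N(C)C`) gives 800 nM, a lower number than both beyond the scatter, so compound 3 sits with compound 2 at the top of this small set.

Compound 4 (`CCCCCCCCCCCC/C=C/c1ccc(CO[C@H]2CN[C@H](CO)C2)cc1`) keeps the core and the configuration of compound 3. The structural change is octyl in place of hydrogen on a saturated chain carbon, four bonds along the chain from a double-bonded chain carbon.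

Among the measured compounds shown here, the only measured step, a 1.0-fold higher number from compound 2 to compound 3 (0.02 log units; within the scatter), stays within the scatter, and the fact that compounds 2 and 3 differ only in the configuration as drawn means that it carries no information on a change in the chain. For the measured compounds named here, no measured step covers a change of this kind. Going by the values given here, the sole remaining guide is compound 1 at 800 nM, whose core differs from that of compound 3 and which shows only that lower numbers occur in this set. A modest move towards a lower number in this assay is therefore expected, on thin support, and a result within the scatter of compound 3 would not surprise. The expected change is a 2.3-fold lower number from compound 3 to compound 4 (0.36 log units; beyond the scatter). For compound 4 the estimated value is 2500 nM, with an expected range from 800 nM to 7500 nM.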

Compound 4, half-maximal inhibitory concentration: 7300 nM
Beside the measured number, compound 4's estimate is 2.9-fold (0.47 log units) below it; low and high end bracket the measured number.
By their numbers in this assay, from the lowest: compound 1; then compounds 2, 3 and 4 (each within the scatter of the next).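

In this assay, octyl in place of hydrogen on a saturated chain carbon, four bonds along the chain from a double-bonded chain carbon, gives a 1.3-fold higher number from compound 3 to compound 4 (0.11 log units; within the scatter), so this place accepts the octyl group with no change that can be told from the scatter. Among the compounds shown here, this is the first step to read a change in the chain, whereas the earlier step, a 1.0-fold higher number from compound 2 to compound 3 (0.02 log units; within the scatter), reads configuration only; on the shared core, neither step moves the number beyond the scatter. Nothing at hand bears on why the added octyl leaves the number level.

Still open, as far as these compounds go, is whether the number stays level with a longer chain than that of compound 4, or with a chain ending in an amine or a carboxylic acid at the same place. Also open, from the compounds shown here alone, is whether the octyl change reads the same on the configuration of compound 2, and which feature of compound 1 goes with its value of 800 nM.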